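This account rests on a few compounds, and the source may have more. Where it says the series, first, only, none or still open, it means among the compounds named here.

Measured so far:
compound 1 `CCCCCCCCc1cn([C@@H]2O[C@@H]3COP(=O)(O)O[C@H]3[C@H]2O)c(=O)nc1N`: in a functional assay on L1210 cells (Mus musculus) for cytotoxicity (on this read-out higher numbers stand for weaker inhibition and lower numbers for stronger inhibition), compound 1 gives > 200 ug/mL, which is a limit of the assay and not a number.
compound 2 `CCc1cn([C@@H]2O[C@@H]3COP(=O)(O)O[C@H]3[C@H]2O)c(=O)nc1N`: in this assay compound 2 gives > 200 ug/mL, again a limit of the assay.

Compound 2 therefore stands at the limit, and both values shown sit there (the limit of > 200 ug/mL in this assay, at which 2 of the 2 values shown sit). Among the measured compounds shown here, the one measured step, from compound 1 to compound 2, reads a step that the two limits leave unreadable from compound 1 to compound 2 and gives no usable size.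

Compound 3 `CCCCc1cn([C@@H]2O[C@@H]3COP(=O)(O)O[C@H]3[C@H]2O)c(=O)nc1N` differs from compound 2 by ethyl in place of hydrogen on a saturated chain carbon, two bonds along the chain from an aromatic carbon. For the measured compounds named here, the only step that bears on this change is the one from compound 1 to compound 2, which the two limits leave unreadable, so no direction or size beyond the scatter can be read from it. With both neighbours at the limit, the step from compound 2 to compound 3 is expected to be a step that the limit leaves unreadable from compound 2 to compound 3, that is, no readable change.

Compound 3 is estimated at 300 ug/mL in this assay, within 150 ug/mL to 1000 ug/mL, and most likely reported only as a limit.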

Compound 3, concentration for 50% inhibition: > 200 ug/mL
Compound 3 ended at the assay's limit; the forecaster's own chance of this, stated with the estimate: 85%; the middle value does not contradict the limit.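

No step among compound 1, compound 2 and compound 3 can be read, as all three values in this assay are limits of the assay and not numbers: the limit of > 200 ug/mL in this assay, at which 3 of the 3 values shown sit.

The compounds shown leave open whether any chain on the shared core gives a readable value in this assay.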